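Notes on the hydroxy position, from compound 2 to compound 4

The compounds below may be only part of what the source reports. "The series", "measured", "known", "first", "only" and "open" are said of these compounds alone.

Compound 1 `CC(Oc1ccccc1-c1ccccc1[N+](=O)[O-])C1=NCCN1`: < 0.3 in a functional assay on CHO cells for agonist activity at Alpha-2C adrenergic receptor (Homo sapiens) (on this read-out higher numbers stand for larger maximal responses and lower numbers for smaller maximal responses), a limit.
Compound 2 `CC(Oc1ccccc1-c1ccccc1O)C1=NCCN1`: < 0.3, a limit.
Compound 3 `CC(Nc1ccccc1-c1ccccc1)C1=NCCN1`: 0.7.

Compound 2 stands at the limit of this assay, as the evidence shows (the limit of < 0.3 in this assay, at which 2 of the 3 values shown sit). For the measured compounds named here, the one measured step, a step that the two limits leave unreadable from compound 1 to compound 2, has a size the two limits leave unreadable. Compound 4 `CC(Oc1ccccc1-c1ccc(O)cc1)C1=NCCN1` differs from compound 2 by 4-hydroxyphenyl in place of 2-hydroxyphenyl on an aromatic carbon. Going by the values given here, no measured step bears on this change; compound 3 carries a different linker and an unsubstituted ring, so it shows only its own value. Since compound 2 gives only a limit, the step of a number no lower from compound 2 to compound 4 (the limit leaves the size open) is expected to be small, and the chance of another limit is high. For compound 4 a value of 0.3 is expected, between 0.1 and 0.5.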

Compound 4, intrinsic activity: the largest response reached, as a fraction of the reference agonist's: < 0.3
Compound 4 was reported as a limit (the forecaster's own chance of this, stated with the estimate: 50%); the middle value sits exactly at the limit.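

Compound 2 and compound 4 both stand as limits in this assay, so the step between them cannot be read. The compounds shown leave open whether 4-hydroxyphenyl in place of 2-hydroxyphenyl changes the maximal response at all.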